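A few compounds are considered here, and "the series" means these few. Any claim that something is new, unique, unknown or untested is made for them only; others in the source may bear on it.

Compound 1 `[O-][n+]1nc(N[C@@H]2C[C@H]3CC[C@@H]2C3)[n+]([O-])c2ccc(F)cc21`: < 2.5 ug/mL
Compound 2 `[O-][n+]1nc(NC2CCCCC2)[n+]([O-])c2ccc(Cl)cc21`: 2.6 ug/mL

Going by the values given here, in an ADME assay on Vero cells (Chlorocebus sabaeus) for cytotoxicity, read by CellTiter-Glo, with a stated time of 72 h (on this read-out lower numbers stand for higher toxicity in this test and higher numbers for lower toxicity in this test), compound 2 gives 2.6 ug/mL, the only actual number so far. Compound 1 gives < 2.5 ug/mL, which is a limit and not a number. Compound 3 `[O-][n+]1nc(N[C@@H]2C[C@H]3CC[C@@H]2C3)[n+]([O-])c2ccc(Cl)cc21` differs from compound 2 in one place: a group of 7 heavy atoms (7 carbon; 2 five-membered non-aromatic rings of carbon only) in place of a group of 6 heavy atoms (6 carbon; one six-membered non-aromatic ring of carbon only), on a nitrogen on an aromatic ring. Among the compounds with values here, no measured pair shows the effect of this change, so only a step within the scatter, in neither direction, is expected in this assay. The estimated change is a 1.0-fold lower number from compound 2 to compound 3 (0.02 log units; within the scatter). For compound 3, the expected value is 2.5 ug/mL, with an estimated range of 1.3 ug/mL to 5 ug/mL.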

Compound 3, half-maximal cytotoxic concentration: 1.1 ug/mL
Beside the measured number, compound 3's estimate is 2.3-fold (0.36 log units) above it; the measured number lies below the stated range.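

On the nitrogen on an aromatic ring, the carbon-only group with 2 five-membered non-aromatic rings in place of cyclohexyl gives, in this assay, a 2.4-fold lower number from compound 2 to compound 3 (0.37 log units; beyond the scatter). Going by these compounds alone, this is the only readable step at this position, modest in size, and it runs toward higher toxicity in this test. The step between fluoro and chloro cannot be read, since compound 1 stands at a limit and not a number: the limit of < 2.5 ug/mL in this assay, at which 1 of the 3 values shown sits.

As far as these compounds go, it stays open what a straight butyl chain or a cyclohexyl carrying a hydroxyl group would give on that nitrogen. From the compounds shown here alone, whether the step at this position holds with fluoro in place of chloro also stays open.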